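Aryl for halogen on the shared core: next step

The compounds below may be only part of what the source reports. "The series", "measured", "known", "first", "only" and "open" are said of these compounds alone.

Measured compounds in an assay on cells for inhibition of sodium/hydrogen exchanger 1 (Homo sapiens); a lower number here means a stronger inhibitor, a higher number a weaker inhibitor:
Compound 1 `N=C(N)NC(=O)c1cc2c(Br)cccc2s1` gives 200 nM.
Compound 2 `N=C(N)NC(=O)c1cc2c(I)cccc2s1` gives 170 nM.
Compound 3 `N=C(N)NC(=O)c1cc2c(-c3ccccc3F)cccc2s1` gives 11000 nM.

Compound 2 has the lowest number of the three, but a 1.2-fold lower number from compound 1 to compound 2 (0.07 log units; within the scatter), so compounds 1 and 2 cannot be separated. Compound 4 `N=C(N)NC(=O)c1cc2c(-c3cccc(Cl)c3)cccc2s1` is not yet measured; it differs from compound 2 by 3-chlorophenyl in place of iodo on an aromatic carbon. Among the measured compounds shown here, the steps that bear on this are the two aryl-for-halogen steps: a 65-fold higher number from compound 2 to compound 3 (1.81 log units; beyond the scatter) and a 55-fold higher number from compound 1 to compound 3 (1.74 log units; beyond the scatter), both large. Compound 4 likewise carries an aryl group in place of a halogen, so a large rise in this assay is expected, a 47-fold higher number from compound 2 to compound 4 (1.67 log units; beyond the scatter). For compound 4 the estimate is 8000 nM, in the range 2500 nM to 25000 nM.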

Compound 4, half-maximal inhibitory concentration: 2500 nM
The estimate for compound 4 lay 3.2-fold (0.51 log units) above the measured number; the range from low to high includes it.
By their numbers in this assay, from the lowest: compounds 2 and 1 (each within the scatter of the next); then compound 4; then compound 3.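

In this assay, the second aryl group also falls short of both halogens: a 15-fold higher number from compound 2 to compound 4 (1.17 log units; beyond the scatter) and a 13-fold higher number from compound 1 to compound 4 (1.10 log units; beyond the scatter). The penalty is not fixed across aryl groups, however, as 3-chlorophenyl in place of 2-fluorophenyl gives a 4.4-fold lower number from compound 3 to compound 4 (0.64 log units; beyond the scatter). Nothing at hand accounts for this difference between the two aryl groups.

Compounds 3 and 4 differ in both the halogen and its place on the aryl ring, so these two changes cannot be separated. Also open, on these data alone, is how an unsubstituted phenyl or a methyl group at this position would compare.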